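The source may report more compounds than this note shows. Statements on the series, on what has been measured and on what is new or still open speak of the compounds shown alone.

Measured in a functional assay on SW480 cells (Homo sapiens) for antiproliferative activity, read by MTT assay, with a stated time of 48 h; on this read-out higher numbers stand for weaker inhibition and lower numbers for stronger inhibition:

compound 1 `CCCC(CCO)n1cnc2c(Cl)nc(F)nc21` gives 17200 nM
compound 2 `CCCC(CCO)n1cnc2c(Cl)ncnc21` gives > 50000 nM
compound 3 `C=C(CO)C(CCCCCCC)n1cnc2c(Cl)ncnc21` gives 29400 nM

Going by the values given here, compound 1 and compound 3 hold the only two real numbers in this small set, and these lie within the scatter of each other. Compound 2 gave > 50000 nM as its entry, which is a limit of the assay and not a number.

The next compound, compound 4 `CC(C)(C)[Si](C)(C)OCC(CCO)n1cnc2c(Cl)nc(F)nc21`, keeps the core of compound 1 with its fluoro and changes only the chain (a group of 8 heavy atoms (6 carbon, 1 oxygen, 1 silicon; no ring) in place of a group of 2 heavy atoms (2 carbon; no ring), on a saturated chain carbon, two bonds along the chain from an aromatic nitrogen). Among the compounds with values here, the sole measured step is an at least 2.9-fold higher number from compound 1 to compound 2 (0.46 log units; beyond the scatter) and it lies beyond the scatter, but it exchanges fluoro for hydrogen on an aromatic carbon and leaves the chain untouched. It therefore gives no size for the present change. A different chain appears only in compound 3 , which gives 29400 nM while also lacking the fluoro. That value offers no sign of a large effect from the chain, though the comparison is not a clean one. No step beyond the scatter is therefore expected in this assay, with a slight lean towards a lower number. The expected change is a 1.6-fold lower number from compound 1 to compound 4 (0.19 log units; within the scatter) and it stays within the scatter. The estimate for compound 4 is 11000 nM with an expected range from 4000 nM to 30000 nM and no firmer claim.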

Compound 4, half-maximal inhibitory concentration: 8020 nM
For compound 4 the middle estimate is 1.4-fold (0.14 log units) above the measured one; low and high end bracket the measured number.
By their numbers in this assay, from the lowest: compound 4; then compounds 1 and 3 (each within the scatter of the next). At a limit, above all of these: compound 2.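

In this assay, going by these compounds alone, the change at the chain gives a 2.1-fold lower number from compound 1 to compound 4 (0.33 log units; beyond the scatter), the first measured step at this position, on a saturated chain carbon, two bonds along the chain from an aromatic nitrogen. Within the data shown here, the only earlier step concerned fluoro on an aromatic carbon, and compound 3 differs from compound 1 in more than one place, so neither could show that replacing ethyl with a group of 8 heavy atoms (6 carbon, 1 oxygen, 1 silicon; no ring) brings no loss of antiproliferative activity and instead a modest gain, with the fluoro kept in place. The entry for compound 2 remains a limit of the assay and not a number: the limit of > 50000 nM in this assay, at which 1 of the 4 values shown sits.

The compounds shown do not separate what the single exchange bundles together, the larger count of heavy atoms, the silicon and the oxygen, so the step cannot be assigned to any one of them. As far as these compounds go, whether a plain longer carbon chain, a hydroxyl or an amine at this position would give a similar number stays open, as does whether the same group would act alike on the core without fluoro.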